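Swapping the Acetylphenyl for Thiophene: What to Expect

A few compounds are considered here, and "the series" means these few. Any claim that something is new, unique, unknown or untested is made for them only; others in the source may bear on it.

Measured so far:
compound 1 `c1ccc(-c2cn3ccnc3c(-c3ccc4ncn(C5CCCCC5)c4c3)n2)cc1`: -11.1%
compound 2 `O=Cc1ccc(-c2cn3ccnc3c(-c3ccc4ncn(C5CCCCC5)c4c3)n2)cc1`: 98%
compound 3 `CC(=O)c1ccc(-c2cn3ccnc3c(-c3ccc4ncn(C5CCCCC5)c4c3)n2)cc1`: 54.4%

All three compounds share one core and differ only in the aryl group attached to it, and all were tested in a functional assay on T47D cells (Homo sapiens) for inhibition, read by sulforhodamine B assay, with a stated time of 48 h, tested at 10 uM; on this read-out higher numbers stand for more inhibition at the one concentration tested (going by the name of the read-out) and lower numbers for less inhibition. Compound 3 stands second highest of the three numbers: a number 43.6 percentage points lower from compound 2 to compound 3 (beyond the scatter), while a number 65.5 percentage points higher from compound 1 to compound 3 (beyond the scatter).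

Compound 4 `c1csc(-c2cn3ccnc3c(-c3ccc4ncn(C5CCCCC5)c4c3)n2)c1` differs from compound 3 in one place: thiophen-2-yl in place of 4-acetylphenyl on an aromatic carbon. Going by the values given here, two measured steps bear on this. Both carbonyl-bearing groups lifted the read-out far above the bare phenyl of compound 1: a number 109.1 percentage points higher from compound 1 to compound 2 (beyond the scatter) and a number 65.5 percentage points higher from compound 1 to compound 3 (beyond the scatter). The step to compound 4 removes the acetyl along with its carbonyl and leaves a small aromatic ring with no such group, a situation closest to compound 1. A large fall in this assay is therefore expected, roughly back toward the level of compound 1, because a number 65.5 percentage points higher from compound 1 to compound 3 (beyond the scatter) is what the acetyl alone was worth. Compound 4 is expected to give 5%, in the range -25% to 45%, a step of a number 49.4 percentage points lower from compound 3 to compound 4 (beyond the scatter).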

Compound 4, a percentage reported as inhibition, at one concentration (the size of the read-out at that concentration, not a potency): 70.3%
Beside the measured number, compound 4's estimate is 65.3 percentage points below it; the measured number lies above the stated range.
By their numbers in this assay, from the lowest: compound 1; then compound 3; then compound 4; then compound 2.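

Replacing the ring itself can carry the read-out high with no carbonyl group present: in this assay there is a number 81.4 percentage points higher from compound 1 to compound 4 (beyond the scatter), so a carbonyl on the aryl group is not required at this position. The thiophen-2-yl group, with fewer heavy atoms than either carbonyl-bearing group, gives a number 15.9 percentage points higher from compound 3 to compound 4 (beyond the scatter) but also a number 27.7 percentage points lower from compound 2 to compound 4 (beyond the scatter), which places it between the 4-acetylphenyl and 4-formylphenyl compounds. Nothing measured here explains why this five-membered ring differs so sharply from phenyl.

The compounds shown leave open whether the sulfur or the five-membered ring shape matters more, a question that a furan-2-yl group, with oxygen in place of sulfur, could help to separate. They also leave open how a thiophen-2-yl group carrying a formyl or acetyl substituent would behave.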